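The compounds below may be only part of what the source reports. "The series", "measured", "known", "first", "only" and "open" are said of these compounds alone.

Measured in an ADME assay on Karpas-1106P cells (Homo sapiens) for cytotoxicity; on this read-out higher numbers stand for an effect only at larger amounts of compound and lower numbers for an effect already at smaller amounts:
- compound 1 `COc1cccc(C(=O)NCCNC(=O)[C@H](CC(=O)NC(C)(C)C)NS(=O)(=O)c2ccc(C)cc2)c1`: > 11100 nM, a limit
- compound 2 `Cc1ccc(S(=O)(=O)N[C@@H](CC(=O)NC(C)(C)C)C(=O)NCCNC(=O)c2ccccc2F)cc1`: > 11100 nM, a limit
- compound 3 `Cc1ccc(S(=O)(=O)N[C@@H](CC(=O)NC(C)(C)C)C(=O)NCCNC(=O)c2ccc(F)cc2)cc1`: > 11100 nM, a limit

Compound 3 has no number in this assay, only the limit > 11100 nM. It shares this position with the other two compounds: the limit of > 11100 nM in this assay, at which 3 of the 3 values shown sit.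

Compound 4 `Cc1ccc(S(=O)(=O)N[C@@H](CC(=O)NC(C)(C)C)C(=O)NCCNC(=O)c2cccc(F)c2)cc1` has 3-fluorophenyl in place of 4-fluorophenyl on a carbonyl carbon.

The closest measured change is a step that the two limits leave unreadable from compound 2 to compound 3, which also exchanges one fluorophenyl for another at this place. The other two, a step that the two limits leave unreadable from compound 1 to compound 2 and a step that the two limits leave unreadable from compound 1 to compound 3, start from 3-methoxyphenyl. None of the three has a size that can be carried over, so they give no direction.

Compound 4 is expected to sit close to compound 3, with no step beyond the scatter, and the estimated change is a step that the limit leaves unreadable from compound 3 to compound 4. For compound 4 the estimate is 12000 nM, expected within 6000 nM to 25000 nM, and a report as a limit is the likeliest outcome.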

Compound 4, half-maximal effective concentration: > 11100 nM
Compound 4 was reported as a limit; the forecaster's own chance of this, stated with the estimate: 88%; the middle value is on the limit's open side.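

In this assay, going by these compounds alone, compound 4 gives the limit > 11100 nM and no step to it from compound 1, compound 2 or compound 3 can be read. Left open is whether exchanging 2-fluorophenyl, 3-fluorophenyl, 4-fluorophenyl or 3-methoxyphenyl changes the read-out at all, with every compound in one position: the limit of > 11100 nM in this assay, at which 4 of the 4 values shown sit.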